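This account rests on a few compounds, and the source may have more. Where it says the series, first, only, none or still open, it means among the compounds named here.

In a functional assay on Caco-2 cells (Homo sapiens) for inhibition, read by MTT assay, with a stated time of 48 h (a lower number here means a stronger inhibitor of growth, a higher number a weaker inhibitor of growth), three measured compounds share one core and differ only in the phenyl group at the end of a double-bonded chain. Compound 1 `CN1CC[C@H](c2c(O)cc(O)c3c(=O)cc(/C=C/c4ccccc4)oc23)[C@H](O)C1`, with no substituent on that phenyl group, gives 3700 nM. Compound 2 `CN1CC[C@H](c2c(O)cc(O)c3c(=O)cc(/C=C/c4cccc(Cl)c4)oc23)[C@H](O)C1` carries a chloro group there and gives 9000 nM, and compound 3 `CN1CC[C@H](c2c(O)cc(O)c3c(=O)cc(/C=C/c4cccc(F)c4)oc23)[C@H](O)C1` carries a fluoro group and gives 8000 nM. The two halogen-bearing compounds cannot be told apart, as the swap of chloro for fluoro shows: a 1.1-fold lower number from compound 2 to compound 3 (0.05 log units; within the scatter). Both sit apart from compound 1, through the modest steps of a 2.4-fold higher number from compound 1 to compound 2 (0.39 log units; beyond the scatter) and a 2.2-fold higher number from compound 1 to compound 3 (0.33 log units; beyond the scatter).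

The next compound, compound 4 `CN1CC[C@H](c2c(O)cc(O)c3c(=O)cc(/C=C/c4ccccc4Cl)oc23)[C@H](O)C1`, has 2-chlorophenyl in place of 3-fluorophenyl on a double-bonded chain carbon bound to a double-bonded chain carbon. The halogen swap is the step closest to this change, and it lay within the scatter. Among the compounds with values here, the modest steps from compound 1 mark how far a single halogen has moved the number so far. Within the data shown here, no measured compound carries the 2-chlorophenyl group, so the data cannot show what this placement does. No step beyond the scatter is expected, and the estimated change is a 1.1-fold lower number from compound 3 to compound 4 (0.06 log units; within the scatter). For compound 4 the estimated value is 7000 nM, with an expected range of 3000 nM to 16000 nM.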

Compound 4, concentration for 50% growth inhibition: 9000 nM
Estimate against measurement, compound 4: 1.3-fold (0.11 log units) below, and the stated range covers the measured number.
By their numbers in this assay, from the lowest: compound 1; then compounds 3, 2 and 4 (each within the scatter of the next).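

In this assay, within the data shown here, this is the first comparison of two placements of the same halogen on the phenyl group, and 2-chlorophenyl in place of 3-chlorophenyl gives no change at the digits printed from compound 2 to compound 4 (within the scatter). The exchange of 3-fluorophenyl for 2-chlorophenyl, with a 1.1-fold higher number from compound 3 to compound 4 (0.05 log units; within the scatter), adds that neither the halogen nor these two placements separates the three halogen-bearing compounds, while the hydrogen-to-chloro change at the new placement, a 2.4-fold higher number from compound 1 to compound 4 (0.39 log units; beyond the scatter), keeps compound 1 the strongest inhibitor of growth of the four. No measurement at hand accounts for either the flat steps among the halogen compounds or their gap from compound 1.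

Going by these compounds, whether any group on this phenyl can bring the number below that of compound 1 stays open, and a methoxy group, an amine or a carboxylic acid in place of the halogen would address that question. How a longer chain between the shared core and the phenyl group would read in this assay also remains an open question.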